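Nitro for Trifluoromethyl on the Compound 2 Urea Series

The source may hold more compounds than are shown below. What is called first, only, known or untested is meant among the compounds shown, and "the series" means these compounds.

Of the compounds shown here, three have numbers so far in a functional assay on A2780 cells (Homo sapiens) for inhibition, with a stated time of 72 h; a lower number here means a stronger inhibitor, a higher number a weaker inhibitor. Compound 1 `CC1(C)CC(C)(C)c2cc(NC(=S)Nc3ccc(C(F)(F)F)cc3)ccc2O1` gives 43700 nM. Compound 2 `CCC1(CC)CC(C)(C)c2cc(NC(=O)Nc3ccc(C(F)(F)F)cc3)ccc2O1` gives 2450 nM, and compound 3 `CCC1(CC)CC(C)(C)Oc2ccc(NC(=O)Nc3ccc([N+](=O)[O-])cc3)cc21` gives 2050 nM. Compound 2 thus holds the second highest of the three numbers: its value and that of compound 3 lie within the usual scatter of each other, while compound 1 sits well beyond the scatter with a markedly higher number. Among the compounds with values here, compound 1 and compound 3 each differ from compound 2 in more than one place, so no single-change step is available among the measured set.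

The next compound, compound 4 `CCC1(CC)CC(C)(C)c2cc(NC(=O)Nc3ccc([N+](=O)[O-])cc3)ccc2O1`, keeps the core of compound 2 and carries nitro in place of trifluoromethyl on an aromatic carbon. Compound 3 already bears the nitro-substituted aryl group on a related core, and its value lies within the scatter of compound 2, which gives no sign that this exchange moves this assay in either direction. Compound 4 is therefore expected to change little from compound 2, a step of about a 1.1-fold lower number from compound 2 to compound 4 (0.05 log units; within the scatter), not beyond the scatter. Compound 4 is estimated at 2200 nM, within a range from 900 nM to 5500 nM.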

Compound 4, half-maximal inhibitory concentration: 2170 nM
Compound 4: the middle estimate sits 1.0-fold (0.01 log units) above what was measured; the measured number falls inside the stated range.
By their numbers in this assay, from the lowest: compounds 3, 4 and 2 (each within the scatter of the next); then compound 1.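

Within the data shown here, replacing 4-(trifluoromethyl)phenyl with 4-nitrophenyl on the core of compound 2 gives a 1.1-fold lower number from compound 2 to compound 4 (0.05 log units; within the scatter) in this assay, the first reading of this exchange with nothing else altered. Compound 3 could offer only an indirect hint, as it differs from compound 2 in more than one place; on this core, at this position, the read-out does not tell the two groups apart. No measured property of these groups is available to bear on this result.

Open, as far as these compounds go, is whether a group of another kind at this place, such as an amine or a carboxylic acid, would shift the number beyond the scatter. Also open, from the compounds shown here alone, is what the exchange of urea for thiourea does on its own, as compound 1 differs from compound 2 in more than one place.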